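The compounds below may be only part of what the source reports. "The series", "measured", "known", "first", "only" and "open" are said of these compounds alone.

Of the compounds shown here, three have been measured in a functional assay on ileum for antagonist activity at histamine H1 receptor (Cavia porcellus); a higher number here means weaker binding, a lower number tighter binding. Compound 1 `CC(C)C(=O)/N=C(\N)NCCCc1c[nH]cn1` gives 7760 nM in this assay, the highest of the three numbers. Compound 3 `CN(CCC(=O)/N=C(\N)NCCCc1c[nH]cn1)C(=O)c1cc2ccccc2[nH]1` gives 3020 nM in this assay, a number that lies closest to compound 1 but still beyond the usual scatter. Compound 2 `N/C(=N\C(=O)CCCNC(=O)c1cc2ccccc2[nH]1)NCCCc1c[nH]cn1` gives 741 nM in this assay, the furthest from compound 1 of the three. Compounds 2 and 3 carry a much larger appendage than compound 1, so neither offers a single-point step from which to read the effect of a small change at the carbonyl carbon.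

Compound 4 `CCCC(=O)/N=C(\N)NCCCc1c[nH]cn1` has not yet been measured. It differs from compound 1 in one place: propyl in place of isopropyl on a carbonyl carbon. The atoms are the same and only their joining changes, so no large movement in this assay is anticipated. The step from compound 1 to compound 4 is expected to be a 1.2-fold lower number from compound 1 to compound 4 (0.08 log units; within the scatter), a shift that should stay within the scatter of repeated measurements. Compound 4 is therefore estimated to give 6500 nM in this assay, with a likely range from 2500 nM to 16000 nM.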

Compound 4, dissociation constant: 3550 nM
Beside the measured number, compound 4's estimate is 1.8-fold (0.26 log units) above it; the measured number falls inside the stated range.
By their numbers in this assay, from the lowest: compound 2; then compounds 3 and 4 (each within the scatter of the next); then compound 1.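

Replacing isopropyl with propyl on a carbonyl carbon gives a 2.2-fold lower number from compound 1 to compound 4 (0.34 log units; beyond the scatter) in this assay. The two groups have the same atoms joined differently, so this position responds to how its three carbons are arranged and not only to how many there are. No available evidence accounts for the size or direction of this modest step.

Going by these compounds, it remains open whether a longer chain such as butyl or pentyl, or a ring such as cyclopropyl or phenyl, on this carbonyl carbon would carry the number in this assay further in the same direction. Also open, on these data alone, is how an amine or a carboxylic acid at the end of the propyl chain would change the result.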